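A few compounds are considered here, and "the series" means these few. Any claim that something is new, unique, unknown or untested is made for them only; others in the source may bear on it.

Measured so far in a functional assay on MCF7 cells (Homo sapiens) for cytotoxicity, with a stated time of 72 h; on this read-out higher numbers stand for weaker inhibition and lower numbers for stronger inhibition:
- compound 1 `CC1c2c(-c3ccncc3)c(-c3ccccc3C#N)nn2CC1(C)C`: > 100000 nM
- compound 2 `Cc1cc(-c2c(-c3cccc(C)n3)nn3c2C(C)C(C)(C)C3)ccn1`: > 100000 nM
- compound 3 `CC1(C)Cc2c(-c3ccncc3)c(-c3ccccc3C#N)nn2C1`: > 100000 nM

Compound 1 gives > 100000 nM, which is a limit of the assay and not a number. Compound 2 gives > 100000 nM, which is also a limit. Compound 3 gives > 100000 nM, again a limit. Compound 1 therefore cannot be ranked against the other two, since the data show (the limit of > 100000 nM in this assay, at which 3 of the 3 values shown sit).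

The next compound, compound 4 `Cc1cccc(-c2nn3c(c2-c2ccncc2)C(C)C(C)(C)C3)c1C#N`, keeps the core of compound 1 and changes one place: methyl in place of hydrogen on an aromatic carbon. A methyl takes the place of hydrogen on an aromatic carbon, ortho to a cyano group.

Among the measured compounds shown here, the only measured step that starts from compound 1 is a step that the two limits leave unreadable from compound 1 to compound 3. That step replaces methyl with hydrogen on a saturated ring carbon, not on the aromatic carbon changed here, and it offers no size to carry over. With no readable step to go on, no change beyond the usual scatter is expected in this assay, and no direction can be named. The estimated step is a number no higher from compound 1 to compound 4 (the limit leaves the size open). Most likely, the assay will again report only a limit. For compound 4 the expected value is 100000 nM, with an estimated range from 30000 nM to 300000 nM.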

Compound 4, half-maximal inhibitory concentration: 97000 nM
Estimate against measurement, compound 4: 1.0-fold (0.01 log units) above; the measured number falls inside the stated range.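

In this assay compound 4 gives 97000 nM, the only measured number among the compounds shown, which gives the series a value that can be compared with later ones. Placing a methyl on an aromatic carbon, ortho to a cyano group, gives an at least 1.0-fold lower number from compound 1 to compound 4 (0.01 log units; that floor lies within the scatter), so the real size of the step may be larger than this floor, but nothing shown proves a change beyond the ordinary difference between repeat measurements. Compound 1 gives > 100000 nM, which is a limit of the assay and not a number.

The compounds shown leave open whether any change to this series can bring cytotoxicity well into the measurable range, and the values offer little to build on: the limit of > 100000 nM in this assay, at which 3 of the 4 values shown sit. They also leave open how the same aromatic carbon would respond to an ethyl chain, an amine or a carboxylic acid in place of the methyl, so the effect of this position cannot yet be told apart from the effect of this one small group.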